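Isopropylamide to Dimethylamide: Expected Maximal Response of Compound 4

The source may hold more compounds than are shown below. What is called first, only, known or untested is meant among the compounds shown, and "the series" means these compounds.

Compound 3 `CC(C)NC(=O)CCc1ccc(NCc2cccc(Oc3ccccc3)c2)cc1` stands lowest among the three measured compounds: in a functional assay on CHO cells for agonist activity at Free fatty acid receptor 1 (Homo sapiens), read by a luciferase reporter (on this read-out lower numbers stand for smaller maximal responses and higher numbers for larger maximal responses), compound 3 gives 66%. Compound 1 `O=C(O)c1ccc(NCc2cccc(Oc3ccccc3)c2)cc1` gives 86% and compound 2 `O=C(O)COc1ccc(NCc2cccc(Oc3ccccc3)c2)cc1` gives 84%. Within the data shown here, the step of a number 2 percentage points lower from compound 1 to compound 2 (within the scatter) lies within the scatter, whereas a number 20 percentage points lower from compound 1 to compound 3 (beyond the scatter) and a number 18 percentage points lower from compound 2 to compound 3 (beyond the scatter) both lie beyond it, so the acid-to-amide exchange is the only change in this set that moves the maximal response by a clear margin.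

Compound 4 `CN(C)C(=O)CCc1ccc(NCc2cccc(Oc3ccccc3)c2)cc1` differs from compound 3 by dimethylamino in place of isopropylamino on a carbonyl carbon. Among the measured compounds shown here, none of the measured steps bears directly on this change: the two steps that reach compound 3 replace carboxy or carboxymethoxy with the 2-(isopropylcarbamoyl)ethyl chain, and no measured pair alters what sits on the amide nitrogen. Compound 4 keeps the amide and the chain and changes only the nitrogen substituent. For the measured compounds named here, with no step in the data addressing this position, the account expects compound 4 to behave much like compound 3, with the step of no change at the digits printed from compound 3 to compound 4 (within the scatter) expected to fall within the scatter in this assay. Compound 4 is therefore estimated to give 66%, with a range from 50% to 82%.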

Compound 4, largest response reached (reported as percent of maximum), in percent of the reference or control that the assay uses: 50%
Estimate against measurement, compound 4: 16 percentage points above; the range from low to high includes it.
By their numbers in this assay, from the lowest: compound 4; then compound 3; then compounds 2 and 1 (each within the scatter of the next).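

In this assay, among these compounds, the group on the amide nitrogen proves to be a position that counts: dimethylamino in place of isopropylamino gives a number 16 percentage points lower from compound 3 to compound 4 (beyond the scatter), a change the earlier compounds could not show, since none of them altered this group. The loss also adds to the earlier exchange of the acid groups for the amide chain, and against the two acids the 2-(dimethylcarbamoyl)ethyl chain gives both a number 34 percentage points lower from compound 2 to compound 4 (beyond the scatter) and a number 36 percentage points lower from compound 1 to compound 4 (beyond the scatter), steps printed as large where those to the isopropylamide were modest. Nothing measured here accounts for the drop at the amide nitrogen.

The change removes the amide hydrogen and also alters the carbon groups on the nitrogen, so these compounds leave open which of the two goes with the smaller maximal response. Also open, going by these compounds, is how an N-methyl amide, which keeps the amide hydrogen, or a longer chain on the amide nitrogen such as N-butyl would read out, and whether a carboxylic acid at the end of the same ethyl chain would regain the response of the two acids.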